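Dithiocarbamate benzamides: indoline to pyridinylmethylamino step

The compounds below may be only part of what the source reports. "The series", "measured", "known", "first", "only" and "open" are said of these compounds alone.

Measured compounds:
compound 1, `Nc1ccccc1NC(=O)c1ccc(CSC(=S)N2CCN(C(c3ccccc3)c3ccccc3)CC2)cc1`, 9.9%
compound 2, `Nc1ccccc1NC(=O)c1ccc(CSC(=S)N2CCc3ccccc32)cc1`, 87%
compound 3, `Nc1ccccc1NC(=O)c1ccc(CSC(=S)N2CCN(c3ccc(F)cc3)CC2)cc1`, 48.7%

All three share one amide core and differ only in the amine attached to the thiocarbonyl carbon. In a functional assay on MGC-803 cells (Homo sapiens) for antiproliferative activity, read by CCK-8 assay, with a stated time of 72 h, tested at 8 uM (a higher number here means a stronger effect of the compound at the concentration tested, a lower number a weaker effect), compound 2 gives 87%, the highest of the three numbers; compound 3 sits below it beyond the scatter, and compound 1 lies furthest away, also beyond the scatter. Changing the amine on the thiocarbonyl carbon thus moves the read-out strongly across the measured set.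

Compound 4, `CN(Cc1cccnc1)C(=S)SCc1ccc(C(=O)Nc2ccccc2N)cc1`, has not been measured. It differs from compound 2 by methyl((pyridin-3-yl)methyl)amino in place of 2,3-dihydro-1H-indol-1-yl on a thiocarbonyl carbon. For the measured compounds named here, no pair of measured compounds makes this same change, so the size of the step is open. Since every other replacement of the indoline seen here, in compound 1 and compound 3, gave a lower number than compound 2, a fall beyond the scatter is expected, though its depth is uncertain. Compound 4 is accordingly estimated at 50%, within 15% to 85%, which means an expected step of a number 37 percentage points lower from compound 2 to compound 4 (beyond the scatter).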

Compound 4, a percentage reported as inhibition, at one concentration (the size of the read-out at that concentration, not a potency): 85.5%
Estimate against measurement, compound 4: 35.5 percentage points below; the measured number lies above the stated range.
By their numbers in this assay, from the lowest: compound 1; then compound 3; then compounds 4 and 2 (each within the scatter of the next).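

In this assay, replacing 2,3-dihydro-1H-indol-1-yl with methyl((pyridin-3-yl)methyl)amino on a thiocarbonyl carbon gives a number 1.5 percentage points lower from compound 2 to compound 4 (within the scatter). A high read-out at this position therefore does not depend on the five-membered non-aromatic ring of compound 2, as compound 4 lacks that ring and carries a six-membered aromatic ring with 1 hetero atom instead. No supporting data bear on why these two groups give matching read-outs.

On these data alone, whether the ring nitrogen of the pyridine contributes remains open, and a benzyl(methyl)amino group at the same place would test this directly. The single-concentration read-out also leaves open whether compound 2 and compound 4 would differ in potency.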